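The source may report more compounds than this note shows. Statements on the series, on what has been measured and on what is new or still open speak of the compounds shown alone.

Measured in a functional assay on HepG2 cells (Homo sapiens) for cytotoxicity, read by sulforhodamine B assay, with a stated time of 48 h; a lower number here means a stronger inhibitor, a higher number a weaker inhibitor:
compound 1, `CCOC(=O)c1c(-c2ccccc2)c(C#N)c(=O)n(/N=C(\C)c2ccc(NS(=O)(=O)c3ccc(Cl)cc3)cc2)c1N`, 16800 nM
compound 2, `CCOC(=O)c1c(-c2ccc(C)cc2)c(C#N)c(=O)n(/N=C(\C)c2ccc(NS(=O)(=O)c3ccc(Cl)cc3)cc2)c1N`, 8380 nM
compound 3, `CCOC(=O)c1c(/C=C/c2ccccc2)c(C#N)c(=O)n(/N=C(\C)c2ccc(NS(=O)(=O)c3ccc(Cl)cc3)cc2)c1N`, 10700 nM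

Compound 3 gives the second highest of the three numbers, yet it sits within the scatter of both compound 2 and compound 1, so no order among the three can be read. Compound 4, `CCOC(=O)c1c(-c2ccc(OC)cc2)c(C#N)c(=O)n(/N=C(\C)c2ccc(NS(=O)(=O)c3ccc(Cl)cc3)cc2)c1N`, differs from compound 3 by 4-methoxyphenyl in place of 2-phenylethenyl on an aromatic carbon. The measured steps all concern this same position and all stay within the scatter: a 1.6-fold lower number from compound 1 to compound 3 (0.20 log units; within the scatter), a 1.3-fold higher number from compound 2 to compound 3 (0.11 log units; within the scatter), and a 2.0-fold lower number from compound 1 to compound 2 (0.30 log units; within the scatter), the last being, like the methoxy entering here, a single substituent added to a phenyl group. No step beyond the scatter is therefore expected in this assay: a 1.1-fold lower number from compound 3 to compound 4 (0.05 log units; within the scatter). Compound 4 is estimated at 9500 nM, with a range of 4000 nM to 22000 nM.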

Compound 4, half-maximal inhibitory concentration: 61700 nM
For compound 4 the middle estimate is 6.5-fold (0.81 log units) below the measured one; measured number above the stated range.
By their numbers in this assay, from the lowest: compounds 2, 3 and 1 (each within the scatter of the next); then compound 4.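

In this assay, within the data shown here, the position opposite the ring nitrogen is no longer silent, with the first steps beyond the scatter (these are a 5.8-fold higher number from compound 3 to compound 4 (0.76 log units; beyond the scatter) and a 7.4-fold higher number from compound 2 to compound 4 (0.87 log units; beyond the scatter) and a 3.7-fold higher number from compound 1 to compound 4 (0.56 log units; beyond the scatter)). The methoxy of the 4-methoxyphenyl group thus separates compound 4 from both the methyl of compound 2 and the hydrogen of compound 1, while those two remain within the scatter of each other. No measurement at hand accounts for this shift.
Going by these compounds, it remains open whether the change follows the oxygen of methoxy specifically or extends to other groups on that phenyl group. A hydroxyl, an amine or a longer chain such as ethoxy could help separate these readings.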